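This account rests on a few compounds, and the source may have more. Where it says the series, first, only, none or still open, it means among the compounds named here.

Measured in a functional assay on A549 cells (Homo sapiens) for cytotoxicity, read by MTT assay, with a stated time of 72 h; on this read-out lower numbers stand for stronger inhibition and higher numbers for weaker inhibition:
- compound 1 `O=C1c2c[n+]([O-])c3ccccc3c2C(=O)c2c1c1ccccc1n2Cc1cn([C@H]2O[C@H](CO)[C@@H](O)[C@H]2O)nn1`: 2680 nM
- compound 2 `CCCCN1CCN(CCCCn2c3c(c4ccccc42)C(=O)c2c[n+]([O-])c4ccccc4c2C3=O)CC1`: 550 nM
- compound 3 `O=C1c2c[n+]([O-])c3ccccc3c2C(=O)c2c1c1ccccc1n2Cc1cn([C@@H]2O[C@H](CO)[C@@H](O)[C@H](O)[C@H]2O)nn1`: 560 nM

Compound 2, at 550 nM, lies within the scatter of compound 3, at 560 nM. Compound 1 gives 2680 nM, and the gap between this value and that of compound 2 exceeds the scatter. Compound 4 `CN1CCN(CCCCCn2c3c(c4ccccc42)C(=O)c2c[n+]([O-])c4ccccc4c2C3=O)CC1` departs from compound 2 by (4-methylpiperazin-1-yl)methyl in place of 4-butylpiperazin-1-yl on a saturated chain carbon, four bonds along the chain from an aromatic nitrogen. Among the compounds with values here, the only measured step, a 4.8-fold lower number from compound 1 to compound 3 (0.68 log units; beyond the scatter), exchanges a different group on an aromatic nitrogen, so it offers no direct guide to this change. Within the data shown here, no measured step covers the piperazine chain, and no shift beyond the scatter is expected in this assay. The expected step is a 1.1-fold higher number from compound 2 to compound 4 (0.04 log units; within the scatter). For compound 4 the estimate is 600 nM, with an expected range of 250 nM to 1500 nM.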

Compound 4, half-maximal inhibitory concentration: 870 nM
Beside the measured number, compound 4's estimate is 1.5-fold (0.16 log units) below it; low and high end bracket the measured number.
By their numbers in this assay, from the lowest: compounds 2, 3 and 4 (each within the scatter of the next); then compound 1.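

In this assay, the piperazine chain shows its first measured step, a 1.6-fold higher number from compound 2 to compound 4 (0.20 log units; within the scatter), which stays within the scatter. Here the butyl on the piperazine gives way to methyl while the chain gains a carbon, so the two alterations are read only together, and together they leave no resolved shift. No available evidence accounts for this result.

As far as these compounds go, what each alteration does alone remains open. So does whether a morpholine in place of the piperazine, or a free amine at the chain end, would keep the number within the scatter of compound 2.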